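Removing the tert-butoxycarbonyl group on a second core

The source may report more compounds than this note shows. Statements on the series, on what has been measured and on what is new or still open speak of the compounds shown alone.

The study compares four benzamide-type compounds in a functional assay on RAW264.7 cells (Mus musculus) for inhibition; on this read-out lower numbers stand for stronger inhibition and higher numbers for weaker inhibition. Compound 1 `CC(C)(C)OC(=O)N(Cc1ccco1)C(=O)c1ccc(CN2Cc3ccccc3S2(=O)=O)cc1` gives 10600 nM in this assay. Compound 2 `O=C(NCc1ccco1)c1ccc(CN2Cc3ccccc3S2(=O)=O)cc1` gives 68400 nM, and compound 3 `CC(C)(C)OC(=O)N(Cc1ccco1)C(=O)c1ccc(CN2Cc3ccccc3C2=O)cc1` gives 51800 nM. Compound 4 `O=C(NCc1ccco1)c1ccc(CN2Cc3ccccc3C2=O)cc1` has not yet been measured.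

The same structural change links compound 1 to compound 2 and compound 3 to compound 4: hydrogen in place of tert-butoxycarbonyl on an amide-type nitrogen and (hydrogen in place of tert-butoxycarbonyl on an amide-type nitrogen). The two places are described in identical words. Between the measured pair this change gave a 6.5-fold higher number from compound 1 to compound 2 (0.81 log units; beyond the scatter).

The two cores differ in the way described by a group of 10 heavy atoms (8 carbon, 1 nitrogen, 1 oxygen; one five-membered non-aromatic ring with 1 hetero atom, one six-membered aromatic ring of carbon only) in place of a group of 11 heavy atoms (7 carbon, 1 nitrogen, 2 oxygen, 1 sulfur; one five-membered non-aromatic ring with 2 hetero atoms, one six-membered aromatic ring of carbon only), on a saturated chain carbon bound to an aromatic carbon, and this change gave a 4.9-fold higher number from compound 1 to compound 3 (0.69 log units; beyond the scatter).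

Going by the values given here, compound 3 is already one of the weaker compounds, and nothing among the measured compounds suggests the core change alters how the tert-butoxycarbonyl removal behaves. The step from compound 3 to compound 4 is therefore expected to be about a 5.8-fold higher number from compound 3 to compound 4 (0.76 log units; beyond the scatter), close to the earlier one, because it rests on a 6.5-fold higher number from compound 1 to compound 2 (0.81 log units; beyond the scatter). Compound 4 is estimated at 300000 nM, with a plausible range from 80000 nM to 1000000 nM.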

Compound 4, half-maximal inhibitory concentration: 49700 nM
Estimate against measurement, compound 4: 6.0-fold (0.78 log units) above, outside the stated range (below it).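

On the core of compound 3, hydrogen in place of tert-butoxycarbonyl on the amide-type nitrogen gave a 1.0-fold lower number from compound 3 to compound 4 (0.02 log units; within the scatter) in this assay, so compound 3 and compound 4 cannot be told apart on this read-out. The change therefore did not carry over from the core of compound 1 to the core of compound 3 with the same size, and the two steps differ clearly: the same change on two cores in this assay, a 6.5-fold higher number (0.81 log units; beyond the scatter) from compound 1 to compound 2 and a 1.0-fold lower number (0.02 log units; within the scatter) from compound 3 to compound 4, 6.7-fold (0.83 log units) apart, beyond the scatter of two such steps This shows that, for these two cores, the step measured on one core did not predict the step on the other, but it does not show why the cores differ, nor how the change would behave on any further core.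

The compounds shown leave open whether the step on the core of compound 1 belongs to tert-butoxycarbonyl specifically or would also appear with a smaller group such as acetyl or methyl on that nitrogen. They also leave open how either core would respond to a benzyl group in the same place.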